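Chloro to fluoro swap in two quaternary-tail analogues

The compounds below may be only part of what the source reports. "The series", "measured", "known", "first", "only" and "open" are said of these compounds alone.

Compound 1 `CN(C)c1ccc2c(=O)c(C(=O)Nc3cc(F)cc(F)c3)cn(-c3ccc(OCCCCCCC[N+]45CCN(CC4)CC5)cc3Cl)c2n1`: 40.1%
Compound 2 `CN(C)c1ccc2c(=O)c(C(=O)Nc3cc(F)cc(F)c3)cn(-c3ccc(OCCCCCCC[N+]45CCN(CC4)CC5)cc3F)c2n1`: 9.02%
Compound 3 `CN(C)c1ccc2c(=O)c(C(=O)Nc3cc(F)cc(F)c3)cn(-c3ccc(OCCCCCCC[N+](C)(C)C4CCCCC4)cc3Cl)c2n1`: "not active" (no number reported)

In an assay on LX2 cells for inhibition of COL1A1 promoter (Homo sapiens), read by a luciferase reporter, with a stated time of 24 h, tested at 20 uM (on this read-out higher numbers stand for a stronger effect at the one concentration tested and lower numbers for a weaker effect), compound 1 gives 40.1%. Compound 2 differs from it by fluoro in place of chloro on an aromatic carbon, and this single change made a step of a number 31.1 percentage points lower from compound 1 to compound 2 (beyond the scatter). Compound 3 differs from compound 1 by a group of 9 heavy atoms (8 carbon, 1 nitrogen; one six-membered non-aromatic ring of carbon only) in place of a group of 8 heavy atoms (6 carbon, 2 nitrogen; 2 six-membered non-aromatic rings with 2 hetero atoms each), on a saturated chain carbon, seven bonds along the chain from an oxygen on an aromatic ring; in this assay compound 3 is recorded only as "not active" (no number reported), so no number is known for it. Compound 4 `CN(C)c1ccc2c(=O)c(C(=O)Nc3cc(F)cc(F)c3)cn(-c3ccc(OCCCCCCC[N+](C)(C)C4CCCCC4)cc3F)c2n1` differs from compound 3 by fluoro in place of chloro on an aromatic carbon, the same change at the same kind of place as from compound 1 to compound 2.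

With compound 3 already reported without a number, and with the same change having produced a number 31.1 percentage points lower from compound 1 to compound 2 (beyond the scatter), compound 4 is expected to sit very low, with an estimated inhibition of about 3% in this assay. The expected range for compound 4 runs from -10% to 15%, and compound 4 may well also be reported only as not active.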

Compound 4, a percentage reported as inhibition, at one concentration (the size of the read-out at that concentration, not a potency): "not active" (no number reported)
Compound 4: no number reported; no gap can be computed for the estimate.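

Within the data shown here, compound 3 and compound 4 are both recorded without a number in this assay, so no step between them can be read. From the compounds shown here alone, what the chloro to fluoro swap does with this tail remains open, and no measured evidence bears on this result.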